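This account rests on a few compounds, and the source may have more. Where it says the series, first, only, none or still open, it means among the compounds named here.

Measured so far:
- compound 1: `O=[N+]([O-])c1ccc(Oc2ccc(/C=N/NC(=S)Nc3ccccc3)cc2)cc1` — 4.95
- compound 2: `Fc1ccc(NC(=S)N/N=C/c2ccc(Oc3ccc(Br)cc3)cc2)cc1` — 5.88
- compound 3: `Fc1ccc(NC(=S)N/N=C/c2ccc(Oc3ccccc3)cc2)cc1` — 5.09

These three compounds were all tested in a physicochemical assay for lipophilicity, in phosphate buffer, measured as octanol-water partition, with a stated time of 24 h; a lower number here means a more polar compound, a higher number a more lipophilic compound. Compound 3 stands second highest of the three numbers: compound 1 lies close by, within the scatter, while compound 2 sits clearly higher. Within the data shown here, the one single-point step among them, a number 0.79 log units lower from compound 2 to compound 3 (beyond the scatter), shows that taking away a bromo on an aromatic carbon brings the number down by a modest amount.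

Compound 4, `O=[N+]([O-])c1ccc(Oc2ccc(/C=N/NC(=S)Nc3ccc(F)cc3)cc2)cc1`, is reached from compound 3 by one change: nitro in place of hydrogen on an aromatic carbon, on the ring that carries the aryl ether. Among the measured compounds shown here, no measured step covers a nitro directly. The nearest guide is the pair of compound 1 and compound 3, which differ at two places at once and yet give numbers within the scatter of each other; this suggests the nitro brings little movement in this assay. The step from compound 3 to compound 4 is therefore expected to be small, a number 0.09 log units lower from compound 3 to compound 4 (within the scatter), in no clear direction. Compound 4 is estimated at 5, with a range from 4.5 to 5.5.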

Compound 4, partition coefficient: 4.89
Compound 4: middle estimate off by 0.11 log units, on the high side, within the range that was stated.
By their numbers in this assay, from the lowest: compounds 4, 1 and 3 (each within the scatter of the next); then compound 2.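

In this assay, the change from phenyl to 4-nitrophenyl gives a number 0.20 log units lower from compound 3 to compound 4 (within the scatter), so at this position, para to a large group, nitro and hydrogen cannot be told apart. Bromo at the same position does stand apart, with a number 0.99 log units lower from compound 2 to compound 4 (beyond the scatter), so the group placed here can matter, although nitro does not separate from hydrogen. A single added fluoro also makes no clear difference, with a number 0.06 log units lower from compound 1 to compound 4 (within the scatter), and nothing available explains any of these results.

The compounds shown cover only hydrogen, nitro and bromo at this position, so where an amine, a carboxylic acid or a longer chain would fall remains open. Also open, from the compounds shown here alone, is whether bromo would give a similar step on the core of compound 1, which lacks the fluoro.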